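From Fluoro to Trifluoromethoxy in a Growth Inhibition Series

A few compounds are considered here, and "the series" means these few. Any claim that something is new, unique, unknown or untested is made for them only; others in the source may bear on it.

For the measured compounds named here, in a functional assay on A2780 cells (Homo sapiens) for inhibition, read by sulforhodamine B assay (on this read-out lower numbers stand for stronger inhibition of growth and higher numbers for weaker inhibition of growth), compound 3 (`Fc1ccc(-c2ccc(-c3ccc(-c4nc5ccccc5[nH]4)cc3)cc2)cc1`) stands at 48200 nM as the highest of the three numbers measured so far. Compound 1 (`Cc1ccc2[nH]c(-c3ccc(-c4ccc(-c5cccc(Cl)c5)cc4)cc3)nc2c1`) reads 2800 nM on the same scale and compound 2 (`COc1cc(-c2ccc(-c3ccc(-c4nc5cc(C)ccc5[nH]4)cc3)cc2)cc(OC)c1OC`) reads 190 nM there, and both lie lower than compound 3 by more than the scatter. Compound 4 (`FC(F)(F)Oc1ccc(-c2ccc(-c3ccc(-c4nc5ccccc5[nH]4)cc3)cc2)cc1`) carries trifluoromethoxy in place of fluoro on an aromatic carbon, para to a large group (trifluoromethoxy in place of fluoro on an aromatic carbon). Going by the values given here, no measured pair differs in one place only, so this change has no direct precedent in this assay. Compound 3 sits so high that a lower number is expected, with compound 1 at 2800 nM as the nearest guide, although compound 1 differs from compound 3 in more than one place. The expected change, a moderate one beyond the scatter but with wide uncertainty, is estimated as a step (a 5.4-fold lower number from compound 3 to compound 4 (0.73 log units; beyond the scatter)) toward stronger inhibition. The expected value for compound 4 is 9000 nM with an estimated range of 1000 nM to 50000 nM on this read-out.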

Compound 4, concentration for 50% growth inhibition: 100000 nM
The estimate for compound 4 lay 11-fold (1.05 log units) below the measured number; measured number above the stated range.
By their numbers in this assay, from the lowest: compound 2; then compound 1; then compound 3; then compound 4.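

Trifluoromethoxy in place of fluoro on an aromatic carbon, para to a large group, gives a 2.1-fold higher number from compound 3 to compound 4 (0.32 log units; beyond the scatter) in this assay and provides the first comparison here between compounds that differ in one place only. The step is modest but beyond the scatter, and it runs toward weaker inhibition of growth, so at this position exchanging one heavy atom for five did not strengthen inhibition. No measurement shown here accounts for the direction of this step. The compounds shown leave open how an amine or a hydroxyl group would read at this same position. They also leave open whether the same exchange would run the same way on the core of compound 1 or compound 2.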